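The source may hold more compounds than are shown below. What is called first, only, known or untested is meant among the compounds shown, and "the series" means these compounds.

Of the compounds shown here, three built on one shared core have been measured so far in a functional assay (muscle tissue) with Cavia porcellus as the target; on this read-out lower numbers stand for an effect already at smaller amounts and higher numbers for an effect only at larger amounts of compound. Compound 1 (`COC(=O)C1=C(C)N=C(C)/C(=C(\O)OC)C1c1cccc(N)c1`) gives 2000 nM, compound 2 (`COC(=O)C1=C(C)N=C(C)/C(=C(\O)OC)C1c1ccccc1C#N`) gives 15.9 nM and compound 3 (`COC(=O)C1=C(C)N=C(C)/C(=C(\O)OC)C1c1cccc(C)c1`) gives 110 nM. That places compound 3 second highest of the three numbers, closer to compound 2 than to compound 1.

Compound 4 (`COC(=O)C1=C(C)N=C(C)/C(=C(\O)OC)C1c1ccccc1C`) holds the same atoms as compound 3, joined differently (2-methylphenyl in place of 3-methylphenyl on a saturated ring carbon): 2-methylphenyl in place of 3-methylphenyl on a saturated ring carbon. For the measured compounds named here, no measured pair shows one group changing only its place on the phenyl ring, so the evidence is indirect. The closest comparison is a 6.9-fold higher number from compound 2 to compound 3 (0.84 log units; beyond the scatter), but that step changes the group as well as its place. The step of an 18-fold lower number from compound 1 to compound 3 (1.26 log units; beyond the scatter) and the step of a 130-fold lower number from compound 1 to compound 2 (2.10 log units; beyond the scatter) show that changes on this phenyl ring have shifted the number a long way in this small set. The 2-methylphenyl of compound 4 matches the 2-cyanophenyl of compound 2 in numbering but not in group, so only part of that gap may carry over.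

A modest move toward a lower number is therefore expected, estimated as a 3.1-fold lower number from compound 3 to compound 4 (0.50 log units; beyond the scatter). For compound 4 the estimated value is 35 nM with an expected range from 10 nM to 120 nM.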

Compound 4, half-maximal effective concentration: 6.03 nM
For compound 4 the middle estimate is 5.8-fold (0.76 log units) above the measured one; measured number below the stated range.
By their numbers in this assay, from the lowest: compound 4; then compound 2; then compound 3; then compound 1.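

Moving a single methyl, with the atoms otherwise unchanged, isolates the place of a group on this phenyl ring for the first time: 2-methylphenyl in place of 3-methylphenyl gives an 18-fold lower number from compound 3 to compound 4 (1.26 log units; beyond the scatter) in this assay. That step is far larger than the one that keeps the numbering and changes the group, methyl in place of cyano, which gives a 2.6-fold lower number from compound 2 to compound 4 (0.42 log units; beyond the scatter), while the full span to the aminophenyl compound is a 330-fold lower number from compound 1 to compound 4 (2.52 log units; beyond the scatter), making compound 4 the lowest number of the four. Among these four compounds, then, the two groups named at the 2 position give the two lowest numbers, with no compound going against this, but nothing shown here explains why the place of the methyl matters so much.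

As far as these compounds go, it remains open whether the low number depends on a methyl in particular, or whether a chlorine, a methoxy group or a longer chain such as ethyl on the phenyl ring at that same numbered place would give a similar result. The compounds shown also leave open how the 2-methylphenyl would behave if the methoxycarbonyl group on the shared core were replaced by a longer ester, such as an ethyl ester.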